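A few compounds are considered here, and "the series" means these few. Any claim that something is new, unique, unknown or untested is made for them only; others in the source may bear on it.

Measured so far:
compound 1, `Cc1ccccc1Nc1nc(Nc2ccc(N3CCN(C)CC3)cc2)ncc1Cl`: in an ADME assay on L02 cells (Homo sapiens) for inhibition, read by CCK-8 assay, with a stated time of 48 h (a lower number here means a stronger inhibitor of growth, a higher number a weaker inhibitor of growth), compound 1 gives 6510 nM.
compound 2, `Cc1ccc(CNc2nc(Nc3ccc(N4CCN(C)CC4)cn3)ncc2Cl)cc1`: in this assay compound 2 gives > 100000 nM.

The value for compound 2 is a limit of this assay, not a number, as noted in the limit of > 100000 nM in this assay, at which 1 of the 2 values shown sits. Compound 2 therefore stands at the weak end of what this study shows, while compound 1 sits with a measured number. The step from compound 2 leads to compound 3, `CC(C)c1cccc(Nc2nc(Nc3ccc(N4CCN(C)CC4)cn3)ncc2Cl)c1`, which is not yet measured. The change is 3-isopropylphenyl in place of 4-methylbenzyl on a nitrogen on an aromatic ring, that is, (4-methylbenzyl)amino to (3-isopropylphenyl)amino. Among the compounds with values here, no measured pair isolates this change, so the expected size rests on the two values shown. Compound 1, with an aryl group on the same kind of nitrogen, gives a measured number in this assay, so a move toward stronger growth inhibition is expected, of the size an at least 6.6-fold lower number from compound 2 to compound 3 (0.82 log units; beyond the scatter). Compound 3 is estimated at 15000 nM, within 5000 nM to 60000 nM.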

Compound 3, concentration for 50% growth inhibition: 12500 nM
For compound 3 the middle estimate is 1.2-fold (0.08 log units) above the measured one; low and high end bracket the measured number.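

This is the only step shown at this position that can be read: in this assay, 3-isopropylphenyl in place of 4-methylbenzyl on a nitrogen on an aromatic ring gives an at least 8.0-fold lower number from compound 2 to compound 3 (0.90 log units; beyond the scatter). The value of compound 2 is a limit and not a number, so the step gives only a minimum size: the limit of > 100000 nM in this assay, at which 1 of the 3 values shown sits. The change replaces a benzyl group with a phenyl group and a methyl group with an isopropyl group in one move, and this single step cannot tell the two apart.

The compounds shown leave open whether an unsubstituted phenyl group or a 3-methylphenyl group on this nitrogen would give a similar number. They also leave open how a carboxylic acid or an amine on that ring, or a longer alkyl chain on the nitrogen, would read.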